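A few compounds are considered here, and "the series" means these few. Any claim that something is new, unique, unknown or untested is made for them only; others in the source may bear on it.

Measured so far:
Compound 1, `CC(C)C(=O)N1CCCn2nc(COc3ccccc3)cc21`, gives 59%.
Compound 2, `O=C(c1ccccn1)N1CCCn2nc(COc3ccccc3)cc21`, gives 44%.

Both numbers come from a functional assay on HEK293 cells for positive allosteric modulation of metabotropic glutamate receptor 5 (Homo sapiens), read by calcium flux; on this read-out lower numbers stand for smaller maximal responses and higher numbers for larger maximal responses. Compound 2 stands at the lower of the two values, and its gap to compound 1 is beyond the usual scatter. The next compound, compound 3, `O=C(c1nccs1)N1CCCn2nc(COc3ccccc3)cc21`, has not yet been measured; it differs from compound 2 in one place: 1,3-thiazol-2-yl in place of pyridin-2-yl on a carbonyl carbon. Among the measured compounds shown here, the only measured step so far is a number 15 percentage points lower from compound 1 to compound 2 (beyond the scatter), a modest drop that followed the swap of an isopropyl for a pyridin-2-yl group. For the measured compounds named here, no measured step compares one aromatic ring with another on the carbonyl carbon, so there is no direct guide for the move from pyridin-2-yl to 1,3-thiazol-2-yl. The step is therefore expected to stay within the scatter, a number 1 percentage points higher from compound 2 to compound 3 (within the scatter). Compound 3 is estimated at 45%, with a likely range from 30% to 60%.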

Compound 3, largest response reached (reported as percent of maximum), in percent of the reference or control that the assay uses: 24%
Compound 3: middle estimate off by 21 percentage points, on the high side, and the stated range ends above it.
By their numbers in this assay, from the lowest: compound 3; then compound 2; then compound 1.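

In this assay, among the compounds shown here, the earlier compounds compared only isopropyl with one aromatic ring, whereas this result shows that two aromatic rings on the same carbonyl carbon are not interchangeable: 1,3-thiazol-2-yl in place of pyridin-2-yl gives a number 20 percentage points lower from compound 2 to compound 3 (beyond the scatter). Measured against isopropyl, the same ring gives a number 35 percentage points lower from compound 1 to compound 3 (beyond the scatter), so among these three compounds, isopropyl gives the largest maximal response and both aromatic rings give smaller ones. No measurement shown here explains the difference between the rings.

This change alters the ring size and the hetero atoms together, so the compounds shown cannot separate the two. On these data alone, it also remains open where a plain phenyl, a thiophen-2-yl or a cyclopropyl on this carbonyl carbon would fall relative to these three groups.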